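Inverting the drawn configuration of compound 3

This account rests on a few compounds, and the source may have more. Where it says the series, first, only, none or still open, it means among the compounds named here.

Compound 1, `CCn1cc(Nc2ncc3c(C)nn(-c4ccc(OC)cc4)c3n2)cn1`, 81 nM; compound 2, `COCCNC(=O)CNc1ncc2c(Br)nn(-c3ccc4ncccc4c3)c2n1`, > 1000 nM; compound 3, `COCCNC(=O)[C@H]1CC[C@@H](Nc2ncc3c(Br)nn(-c4ccc5ncccc5c4)c3n2)CC1`, 211 nM.

In an assay on isolated protein for inhibition of eIF-2-alpha kinase GCN2 (Homo sapiens) (on this read-out lower numbers stand for stronger inhibition and higher numbers for weaker inhibition), compound 3 gives 211 nM, the higher of the two numbers reported. Its nearest neighbour is compound 1, which in this assay gives 81 nM, a lower number beyond the scatter. Compound 2 in this assay gives only a limit, > 1000 nM, so it is not a number (the limit of > 1000 nM in this assay, at which 1 of the 3 values shown sits).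

Compound 4, `COCCNC(=O)[C@H]1CC[C@H](Nc2ncc3c(Br)nn(-c4ccc5ncccc5c4)c3n2)CC1`, is related to compound 3 by the two compounds have the same atoms and bonds and differ only in configuration as drawn: 2 of 2 stereo elements differ (all stereocentres are inverted: mirror images); a stereocentre at a saturated ring carbon is drawn s in compound 3 and r in compound 4; a stereocentre at a saturated ring carbon is drawn s in compound 3 and r in compound 4. No step between measured compounds of this kind is shown, so the size and direction of the change are open; a change of modest size, in either direction, is expected. The step from compound 3 to compound 4 is estimated as a 1.7-fold higher number from compound 3 to compound 4 (0.22 log units; within the scatter). Compound 4 is therefore expected to give about 350 nM in this assay, most likely between 100 nM and 1500 nM.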

Compound 4, half-maximal inhibitory concentration: 159 nM
Estimate against measurement, compound 4: 2.2-fold (0.34 log units) above; the range from low to high includes it.
By their numbers in this assay, from the lowest: compounds 1, 4 and 3 (each within the scatter of the next, the first and the last beyond it). At a limit, above all of these: compound 2.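

In this assay, inverting both drawn stereocentres on the saturated ring gives a 1.3-fold lower number from compound 3 to compound 4 (0.12 log units; within the scatter). The earlier compounds shown here offered no such pair, and this one shows that, at this ring, the configuration as drawn does not separate the two compounds on this read-out. The step isolates configuration alone: the fact that compounds 3 and 4 differ only in the configuration as drawn.

From the compounds shown here alone, whether the two configurations stay this close when the amide is replaced by a carboxylic acid or an amine remains open. So does whether they stay this close with a longer chain on the amide.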